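The source may report more compounds than this note shows. Statements on the series, on what has been measured and on what is new or still open speak of the compounds shown alone.

Compound 1 `COc1ccc(-c2cn3ccnc3c(-c3ccc4ncn(C5CCCCC5)c4c3)n2)cc1`: 31.5%
Compound 2 `O=Cc1ccc(-c2cn3ccnc3c(-c3ccc4ncn(C5CCCCC5)c4c3)n2)cc1`: 11.2%
Compound 3 `Brc1ccc(-c2cn3ccnc3c(-c3ccc4ncn(C5CCCCC5)c4c3)n2)cc1`: 4.21%

The read-out is a functional assay on NCI-H322M cells (Homo sapiens) for inhibition, read by sulforhodamine B assay, with a stated time of 48 h, tested at 10 uM; a higher number here means more inhibition at the concentration tested (going by the name of the read-out), a lower number less inhibition. In this assay compound 3 gives 4.21%, the lowest of the three numbers shown; compound 2 lies nearest, a step of a number 7 percentage points lower from compound 2 to compound 3 (within the scatter), while compound 1 lies furthest, a step of a number 27.3 percentage points lower from compound 1 to compound 3 (beyond the scatter).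

Compound 4 `FC(F)(F)c1cccc(-c2cn3ccnc3c(-c3ccc4ncn(C5CCCCC5)c4c3)n2)c1` is not yet measured. It differs from compound 3 in one place: 3-(trifluoromethyl)phenyl in place of 4-bromophenyl on an aromatic carbon.

For the measured compounds named here, no measured step changes a phenyl group for a differently substituted phenyl in this way. The steps that come closest each swap the group on the same aromatic carbon: a number 20.3 percentage points lower from compound 1 to compound 2 (beyond the scatter) and a number 27.3 percentage points lower from compound 1 to compound 3 (beyond the scatter) were modest losses, and a number 7 percentage points lower from compound 2 to compound 3 (within the scatter) stayed within the scatter. These show that changing this group can shift the number by a modest amount, but give no direction for a trifluoromethyl-bearing phenyl. A step of no clear direction, possibly within the scatter, is therefore expected: a number 5.8 percentage points higher from compound 3 to compound 4 (within the scatter). Compound 4 is estimated at 10%, with a range from 0% to 30%.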

Compound 4, a percentage reported as inhibition, at one concentration (the size of the read-out at that concentration, not a potency): 5.83%
Compound 4: the middle estimate sits 4.2 percentage points above what was measured, and the stated range covers the measured number.
By their numbers in this assay, from the lowest: compounds 3, 4 and 2 (each within the scatter of the next); then compound 1.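

In this assay the 3-(trifluoromethyl)phenyl group brings a number 1.6 percentage points higher from compound 3 to compound 4 (within the scatter) and a number 5.4 percentage points lower from compound 2 to compound 4 (within the scatter), so on this aromatic carbon it cannot be told apart from 4-bromophenyl or 4-formylphenyl, even though both the substituent and its numbered place on the phenyl differ. For the compounds shown here, the comparison with 4-methoxyphenyl gives a number 25.7 percentage points lower from compound 1 to compound 4 (beyond the scatter), which leaves compound 1 as the only one of the four compounds whose number stands clear of the others, and a substituent at the 3-place of the phenyl has not brought the number back towards it. The compounds shown offer no measurement that could explain this difference.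

As far as these compounds go, the substituent and its place change together in these steps, so it remains open whether a 3-methoxyphenyl group would keep the number of compound 1 or a 4-(trifluoromethyl)phenyl group would match compound 4. Also open, from the compounds shown here alone, is how a phenyl carrying an amine, a hydroxyl or a carboxylic acid would read at this position.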